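From compound 2 to compound 3: one aryl group exchanged

This account rests on a few compounds, and the source may have more. Where it says the series, first, only, none or still open, it means among the compounds named here.

compound 1 `COc1cccc(-c2ccc(C(=O)N(Cc3cccc(OCCCCCC(=O)O)c3)C(C)C)cc2)c1` gives > 20900 nM (a limit)
compound 2 `COc1cc(F)cc(-c2ccc(C(=O)N(Cc3cccc(OCCCCCC(=O)O)c3)C(C)C)cc2)c1` gives > 26000 nM (a limit)

In an ADME assay on Raji cells (Homo sapiens) for cytotoxicity, read by CellTiter-Glo and resazurin assay, with a stated time of 72 h (on this read-out lower numbers stand for an effect already at smaller amounts and higher numbers for an effect only at larger amounts of compound), compound 2 stands at > 26000 nM as a limit and not as a number. Compound 1 likewise stands at > 20900 nM as a limit. Neither compound therefore offers a number to build on. Compound 3 `CC(C)N(Cc1cccc(OCCCCCC(=O)O)c1)C(=O)c1ccc(-c2cccc(Cl)c2)cc1` comes from compound 2 by the change 3-chlorophenyl in place of 3-fluoro-5-methoxyphenyl on an aromatic carbon and by nothing else. In words, 3-chlorophenyl takes the place of 3-fluoro-5-methoxyphenyl on an aromatic carbon. Going by the values given here, the one measured step that the two limits leave unreadable from compound 1 to compound 2 touched that same group, with fluoro in place of hydrogen on an aromatic carbon, and it gives no size to carry over. No step beyond the scatter is therefore expected in this assay and a further limit is the likely report. Compound 3 is estimated at 25000 nM with an expected range from 9000 nM to 50000 nM in this read-out. The expected step is an at least 1.0-fold lower number from compound 2 to compound 3 (0.01 log units; that floor lies within the scatter) and no larger.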

Compound 3, half-maximal effective concentration: > 21900 nM
Compound 3: only a limit was reported; the forecaster's own chance of this, stated with the estimate: 80%; the middle value is on the limit's open side.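

In this assay compound 3 gives > 21900 nM, which is a limit. Compound 1 and compound 2 also stand only as limits, so no step among these three compounds can be read. The compounds shown leave open the concentration at which any of them reaches a half-maximal effect, and whether the aryl exchange changes it.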